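Chloro in place of fluoro: working notes

The source may hold more compounds than are shown below. What is called first, only, known or untested is meant among the compounds shown, and "the series" means these compounds.

In a functional assay (on this read-out higher numbers stand for weaker inhibition and lower numbers for stronger inhibition), compound 1 (`CC(C)=CCOc1ccc2c(c1)OC(c1cccc(Cl)c1)CC2=O`) gives 6300 nM and compound 2 (`CC(C)=CCOc1cc(O)c2c(c1)OC(c1cccc(F)c1)CC2=O`) gives 7240 nM within the scatter of each other. Relative to compound 2, compound 3 (`CC(C)=CCOc1cc(O)c2c(c1)OC(c1cccc(Cl)c1)CC2=O`) carries chloro in place of fluoro on an aromatic carbon, meta to a large group (chloro in place of fluoro on an aromatic carbon). Going by the values given here, no measured step isolates this change in this assay, so no shift beyond the scatter is expected. Compound 1 also holds the 3-chlorophenyl and gives 6300 nM as the nearest reference. The estimated step of a 1.1-fold lower number from compound 2 to compound 3 (0.05 log units; within the scatter) is expected to stay within the scatter. For compound 3 the expected value is 6500 nM with an estimated range from 3200 nM to 13000 nM on this read-out.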

Compound 3, half-maximal inhibitory concentration: 6060 nM
Estimate against measurement, compound 3: 1.1-fold (0.03 log units) above; low and high end bracket the measured number.
By their numbers in this assay, from the lowest: compounds 3, 1 and 2 (each within the scatter of the next).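

In this assay the change from 3-fluorophenyl to 3-chlorophenyl now has a measured size, with a 1.2-fold lower number from compound 2 to compound 3 (0.08 log units; within the scatter) inside the scatter. Hydroxy in place of hydrogen on an aromatic carbon also has a first reading, a 1.0-fold lower number from compound 1 to compound 3 (0.02 log units; within the scatter) and likewise inside the scatter, so neither change separates these compounds on this read-out. No supporting measurement accompanies these numbers. Still open, on these data alone, is whether a group other than fluoro or chloro at this position, such as methoxy or an amine, would give a step beyond the scatter.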